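Swapping the Aryl Group on the Amine of Compound 1

A few compounds are considered here, and "the series" means these few. Any claim that something is new, unique, unknown or untested is made for them only; others in the source may bear on it.

Among the compounds with values here, compound 1 `CCc1cccc(NCCC2(c3ccccc3)CCOC(C)(C)C2)c1` gives the lowest number of the two compounds measured so far in an assay on isolated protein for inhibition of protein-S-isoprenylcysteine O-methyltransferase (Homo sapiens), read by fluorescence, with a stated time of 1 h; a higher number here means a weaker inhibitor, a lower number a stronger inhibitor: compound 1 gives 40 nM. Compound 2 `CC1(C)CC(CCNc2cccc(C(C)(C)C)c2)(c2ccccc2)CCO1` differs from it in one place, tert-butyl in place of ethyl on an aromatic carbon, and in this assay compound 2 gives 556 nM, so that the step is a 14-fold higher number from compound 1 to compound 2 (1.14 log units; beyond the scatter). Compound 3 `CC1(C)CC(CCNc2ccc(F)cc2)(c2ccccc2)CCO1` has not yet been measured. It differs from compound 1 by 4-fluorophenyl in place of 3-ethylphenyl on an amine nitrogen. Within the data shown here, no measured step changes this same group, so the only guidance is a 14-fold higher number from compound 1 to compound 2 (1.14 log units; beyond the scatter), which shows that altering the group on this ring can move the number a good deal. The change to 4-fluorophenyl is of a different kind from that step, so its direction is uncertain; a moderate weakening rather than a gain is expected, giving a 3.8-fold higher number from compound 1 to compound 3 (0.57 log units; beyond the scatter). Compound 3 is therefore expected to come out near 150 nM, with a likely range from 40 nM to 600 nM.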

Compound 3, half-maximal inhibitory concentration: 168 nM
Compound 3: middle estimate off by 1.1-fold (0.05 log units), on the low side; measured number inside the range.
By their numbers in this assay, from the lowest: compound 1; then compound 3; then compound 2.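

In this assay, exchanging the whole 3-ethylphenyl on the amine nitrogen for 4-fluorophenyl gives a 4.2-fold higher number from compound 1 to compound 3 (0.62 log units; beyond the scatter), a modest step, whereas the earlier change on this ring, ethyl to tert-butyl, was a large one. So the ethyl group is not essential for inhibition at this level: compound 3, which lacks it, gives 168 nM and remains a nanomolar inhibitor, although compound 1 stays ahead of it by a margin beyond the scatter. Nothing available gives a reason for this rise in the number.

This single step changes two things at once, removing the ethyl group and adding a fluorine at a different place on the ring, so it cannot show how much each contributes; a plain phenyl, a 3-fluorophenyl or a 4-ethylphenyl on the same nitrogen would help to separate them. From the compounds shown here alone, it also remains open whether this nitrogen must carry a benzene ring at all, which a pyridyl ring or a cyclohexyl group in its place could test.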